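Acyl variation on a dodecylamide threonine series

This account rests on a few compounds, and the source may have more. Where it says the series, first, only, none or still open, it means among the compounds named here.

Compound 1 `CCCCCCCCCCCCNC(=O)[C@@H](NC(=O)c1ccco1)[C@@H](C)O`: 92400 nM in a functional assay on A-431 cells (Homo sapiens) for cytotoxicity, read by MTT assay, with a stated time of 48 h; a higher number here means a weaker inhibitor, a lower number a stronger inhibitor
Compound 2 `CCCCCCCCCCCCNC(=O)[C@@H](NC(=O)/C=C/c1ccccc1)[C@@H](C)O`: > 200000 nM in this assay

Compound 2 sits at the limit of > 200000 nM in this assay, at which 1 of the 2 values shown sits, a limit of this assay and not a number. Within the data shown here, the step of an at least 2.1-fold higher number from compound 1 to compound 2 (0.33 log units; beyond the scatter) is the only measured change at this carbonyl carbon. Compound 3 `C/C=C/C=C/C(=O)N[C@H](C(=O)NCCCCCCCCCCCC)[C@@H](C)O` carries prop-1-en-1-yl in place of phenyl on a double-bonded chain carbon bound to a double-bonded chain carbon. Among the measured compounds shown here, only that one step bears on it, and it pointed to weaker inhibition; compound 3 is expected to stay near the limit, so a number no higher from compound 2 to compound 3 (the limit leaves the size open) is estimated at no change beyond the scatter. Compound 3 is therefore estimated at 200000 nM, with a range of 60000 nM to 500000 nM.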

Compound 3, half-maximal inhibitory concentration: 171000 nM
The estimate for compound 3 lay 1.2-fold (0.07 log units) above the measured number; low and high end bracket the measured number.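

In this assay, a 1.9-fold higher number from compound 1 to compound 3 (0.27 log units; within the scatter), so an acyl group with no ring, penta-1,3-dien-1-yl, reads alongside furan-2-yl at this carbonyl carbon. The change of phenyl to prop-1-en-1-yl gives an at least 1.1-fold lower number from compound 2 to compound 3 (0.06 log units; that floor lies within the scatter), so no change beyond the scatter can be claimed for it. Compound 2 stands at a limit and not a number: the limit of > 200000 nM in this assay, at which 1 of the 3 values shown sits.

Open, as far as these compounds go, is whether an amine or a carboxylic acid on this carbonyl carbon would move the number beyond the scatter. Also open, from the compounds shown here alone, is what a longer chain in place of dodecyl would do.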